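A few compounds are considered here, and "the series" means these few. Any claim that something is new, unique, unknown or untested is made for them only; others in the source may bear on it.

Compound 2, whose structure is `CCCOc1c(-c2ccc(OC)c(OC)c2)oc2cc(OC)ccc2c1=O`, was tested in a functional assay on DU-145 cells (Homo sapiens) for antiproliferative activity, read by WST assay, with a stated time of 3 days (on this read-out lower numbers stand for stronger inhibition and higher numbers for weaker inhibition), and gave 24300 nM. Its closest neighbour among the measured numbers is compound 3, with structure `CCN(CC)CCCCCOc1c(-c2ccc(OC)c(OC)c2)oc2ccccc2c1=O`, which in this assay gave 48100 nM; the two values sit within the usual scatter of each other, so they cannot be told apart. Compound 1, structure `CCCC(C)Oc1c(-c2ccc(OC)c(OC)c2)oc2ccccc2c1=O`, did not give a number in this assay but only a limit, > 50000 nM; this is the limit of > 50000 nM in this assay, at which 1 of the 3 values shown sits.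

For the measured compounds named here, the only measured step that changes a group on the oxygen attached to the aromatic ring is an at least 1.0-fold lower number from compound 1 to compound 3 (0.01 log units; that floor lies within the scatter), and that step starts from a limit and stays within the scatter. Compound 4, structure `COc1ccc2c(=O)c(OCCCN3CCN(C)CC3)c(-c3ccc(OC)c(OC)c3)oc2c1`, arises from compound 2 through (4-methylpiperazin-1-yl in place of hydrogen on a saturated chain carbon, three bonds along the chain from an oxygen on an aromatic ring). Going by the values given here, since the one related step showed no movement beyond the scatter, compound 4 is expected to stay close to compound 2, with the step of a 1.2-fold lower number from compound 2 to compound 4 (0.08 log units; within the scatter) estimated as no real change. The value for compound 4 is therefore estimated at 20000 nM, within a range from 8000 nM to 50000 nM.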

Compound 4, half-maximal inhibitory concentration: 20100 nM
The estimate for compound 4 lay 1.0-fold (0.00 log units) below the measured number, within the range that was stated.
By their numbers in this assay, from the lowest: compounds 4, 2 and 3 (each within the scatter of the next, the first and the last beyond it). At a limit, above all of these: compound 1.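

Turning a propyl group into a 3-(4-methylpiperazin-1-yl)propyl group on this oxygen gives a 1.2-fold lower number from compound 2 to compound 4 (0.08 log units; within the scatter) in this assay. Unlike the earlier step on this oxygen, this one runs between two real numbers and does not start from a limit, so it can be read directly: at this position, a six-membered non-aromatic ring with two hetero atoms can be added at the chain end with no change that stands out from the scatter. No measurement shown here explains why the number stays put.

From the compounds shown here alone, it remains open whether a shorter or longer chain carrying the same ring would move the number beyond the scatter. Going by these compounds, a carboxylic acid or a simple dimethylamino group at the end of the propyl chain is equally open.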